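The source may hold more compounds than are shown below. What is called first, only, known or untested is meant among the compounds shown, and "the series" means these compounds.

Working notes on the series.

Of the compounds shown here, two carry numbers so far. Compound 1, `Cc1cc(O)cc(-c2nn(CC#N)cc2-c2ccnc(-c3ccc(Oc4ccccc4)cc3)c2)c1`, is the hydroxy-bearing member with a phenoxy group on the outer ring; in a functional assay on A549 cells (Homo sapiens) for cytotoxicity, read by sulforhodamine B assay, with a stated time of 48 h, tested at 100 nM (a higher number here means a weaker effect of the compound at the concentration tested, a lower number a stronger effect), compound 1 gives 87%. Compound 2, `COc1cc(C)cc(-c2nn(CC#N)cc2-c2ccnc(-c3ccc(N(C)C)cc3)c2)c1`, carries a methoxy group and a dimethylamino group instead; in this assay compound 2 gives 36%. Among the measured compounds shown here, on these two numbers compound 2 stands lowest, the only other value being that of compound 1, which lies higher by a margin beyond the scatter. For the measured compounds named here, the two compounds differ in more than one place, so no single step between them can be read.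

Compound 3, `Cc1cc(O)cc(-c2nn(CC#N)cc2-c2ccnc(-c3ccc(N(C)C)cc3)c2)c1`, is not yet measured. It differs from compound 2 in one place: hydrogen in place of methyl on an oxygen on an aromatic ring Read one bond further out, the change is methoxy to hydroxy. Going by the values given here, no measured pair shows this change alone, so the size of the step is open. The expectation is a moderate step upward, from compound 2 to compound 3 of a number 16 percentage points higher from compound 2 to compound 3 (beyond the scatter), that is, a somewhat weaker effect. For compound 3 the estimated value in this assay is 52%, within a range of 28% to 80%.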

Compound 3, a percentage reported as activity, at one concentration (the size of the read-out at that concentration, not a potency): 95%
Compound 3: middle estimate off by 43 percentage points, on the low side; measured number above the stated range.
By their numbers in this assay, from the lowest: compound 2; then compounds 1 and 3 (each within the scatter of the next).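

In this assay, methoxy to hydroxy on the aromatic ring, with the dimethylamino group unchanged, gives a large step, a number 59 percentage points higher from compound 2 to compound 3 (beyond the scatter), so in this pair the methyl on the oxygen goes with the stronger effect at the concentration tested. With the hydroxy group unchanged, dimethylamino in place of phenoxy on an aromatic carbon gives a number 8 percentage points higher from compound 1 to compound 3 (within the scatter), so in this pair the exchange of those two groups does not separate the compounds in this read-out, and this position shows far more response to the methoxy to hydroxy change than to that exchange. The compounds carry no measured information that accounts for the large step at the oxygen.

Among the compounds shown here, whether the methoxy to hydroxy step keeps its size with phenoxy in place of dimethylamino stays open, as the one pair showing it carries dimethylamino alone. Also open, on these data alone, is how the read-out would respond to an ethoxy group or an amine in place of methoxy on the same aromatic ring, and so whether the strong effect belongs to methoxy alone or extends to other groups there.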